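A few compounds are considered here, and "the series" means these few. Any claim that something is new, unique, unknown or untested is made for them only; others in the source may bear on it.

Among the measured compounds shown here, compound 1 `Cc1cc(Cl)cc(-c2c(C)nn(-c3nc(-c4ccc(Cl)c(Cl)c4)c(SC(C)C)s3)c2C(=O)O)c1` gives 663 nM in a functional assay on BJAB cells (Homo sapiens) for antiproliferative activity, with a stated time of 4 days (a lower number here means that less compound is needed, a higher number that more compound is needed for the effect), the lowest of the three numbers measured so far. Compound 3 `COc1cc(Cl)cc(-c2c(C)nn(-c3nc(-c4ccc(Cl)c(Cl)c4)c(SC(C)C)s3)c2C(=O)O)c1` gives 760 nM, and the step of a 1.1-fold higher number from compound 1 to compound 3 (0.06 log units; within the scatter) lies within the scatter, so the two compounds are not told apart. Compound 2 `COc1cccc(-c2c(C)nn(-c3nc(-c4ccc(Cl)c(Cl)c4)c(SC(C)C)s3)c2C(=O)O)c1` gives 14000 nM, and the step of a 21-fold higher number from compound 1 to compound 2 (1.32 log units; beyond the scatter) is large, as is the step of an 18-fold lower number from compound 2 to compound 3 (1.27 log units; beyond the scatter), which differs only by chloro in place of hydrogen on an aromatic carbon. Compound 4 `Cc1nn(-c2nc(-c3ccc(Cl)c(Cl)c3)c(SC(C)C)s2)c(C(=O)O)c1-c1ccccc1C(F)(F)F` differs from compound 1 by 2-(trifluoromethyl)phenyl in place of 3-chloro-5-methylphenyl on an aromatic carbon. For the measured compounds named here, no measured step carries a 2-(trifluoromethyl)phenyl, so the bearing of the three steps is indirect: the large steps from compound 1 to compound 2 and from compound 2 to compound 3 show that the phenyl substituent pattern can move this assay well beyond the scatter, while the step from compound 1 to compound 3 shows one exchange that changed nothing beyond the scatter. A loss beyond the scatter is therefore expected, estimated as a 4.5-fold higher number from compound 1 to compound 4 (0.66 log units; beyond the scatter). For compound 4 the expected value is 3000 nM, within a range of 700 nM to 13000 nM.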

Compound 4, half-maximal effective concentration: 5200 nM
Estimate against measurement, compound 4: 1.7-fold (0.24 log units) below; measured number inside the range.
By their numbers in this assay, from the lowest: compounds 1 and 3 (each within the scatter of the next); then compound 4; then compound 2.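

In this assay, 2-(trifluoromethyl)phenyl at this place on the shared core gives a 7.8-fold higher number from compound 1 to compound 4 (0.89 log units; beyond the scatter) and also a 6.8-fold higher number from compound 3 to compound 4 (0.84 log units; beyond the scatter), so it does not match either chloro-bearing phenyl group. It still gives a 2.7-fold lower number from compound 2 to compound 4 (0.43 log units; beyond the scatter), which shows that a phenyl group without chloro need not fall as far as the 3-methoxyphenyl group of compound 2. Across these four compounds, the two phenyl groups that carry chloro give the lowest numbers, and no compound goes against this.

The data shown offer no evidence on why these groups differ. Still open, going by these compounds, is what the trifluoromethyl group and its place on the phenyl ring each contribute, and how an unsubstituted phenyl or a phenyl bearing an amine or a nitrile would compare.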